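Moving the Methoxy Group on the Carbamate Aryl Ring

A few compounds are considered here, and "the series" means these few. Any claim that something is new, unique, unknown or untested is made for them only; others in the source may bear on it.

In a functional assay on PANC-1 cells (Homo sapiens) for inhibition, read by MTT assay, with a stated time of 24 h, tested at 10 uM (a higher number here means more inhibition at the concentration tested (going by the name of the read-out), a lower number less inhibition), compound 3 `COc1ccc(NC(=O)Oc2cc(=O)n(CCCO)c3c2CC(C/C=C(\C)CCC=C(C)C)C(C)(C)C3)cc1` gives 64.1%. Of the three measured compounds it stands second highest: compound 1 `CCOc1cc(=O)n(CCCO)c2c1CC(C/C=C(\C)CCC=C(C)C)C(C)(C)C2` is nearest at 67.8%, a gap within the scatter, while compound 2 `CC(C)=CCC/C(C)=C/CC1Cc2c(OCC=C(C)C)cc(=O)n(CCCO)c2CC1(C)C` is furthest at 30.3%, a gap beyond it. The change to compound 4 `COc1cccc(NC(=O)Oc2cc(=O)n(CCCO)c3c2CC(C/C=C(\C)CCC=C(C)C)C(C)(C)C3)c1` is 3-methoxyphenyl in place of 4-methoxyphenyl on an amide-type nitrogen. Among the measured compounds shown here, no measured step touches this part of the molecule: a number 3.7 percentage points lower from compound 1 to compound 3 (within the scatter) exchanges the whole group on the ring oxygen, and a number 37.5 percentage points lower from compound 1 to compound 2 (beyond the scatter) and a number 33.8 percentage points higher from compound 2 to compound 3 (beyond the scatter) likewise concern that oxygen substituent. Rearranging the same atoms within the carbamate aryl ring therefore gives no basis for expecting a step beyond the scatter in this assay. The expected step is a number 1.1 percentage points lower from compound 3 to compound 4 (within the scatter), within the scatter. Compound 4 is estimated at 63%, between 45% and 78%.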

Compound 4, a percentage reported as inhibition, at one concentration (the size of the read-out at that concentration, not a potency): 47%
For compound 4 the middle estimate is 16 percentage points above the measured one, and the stated range covers the measured number.
By their numbers in this assay, from the lowest: compound 2; then compound 4; then compounds 3 and 1 (each within the scatter of the next).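

In this assay, the aryl ring of the carbamate proves not to be a neutral part of the molecule: with the same atoms joined differently, 3-methoxyphenyl in place of 4-methoxyphenyl gives a number 17.1 percentage points lower from compound 3 to compound 4 (beyond the scatter). The 3-methoxyphenyl carbamate also separates from the ethyl ether, with a number 20.8 percentage points lower from compound 1 to compound 4 (beyond the scatter), while it stays clear of the 3-methylbut-2-en-1-yl ether, with a number 16.7 percentage points higher from compound 2 to compound 4 (beyond the scatter). No measurement shown here explains the effect of this move. On these data alone, how an unsubstituted phenyl, or a chlorine or hydroxyl in place of the methoxy, would read remains open.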